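Tert-butyl in place of methyl on the shared core

A few compounds are considered here, and "the series" means these few. Any claim that something is new, unique, unknown or untested is made for them only; others in the source may bear on it.

Working notes on two measured compounds and one to be measured. In a functional assay on the whole organism (strain Swiss albino) for inhibition, with Mus musculus as the target, in the writhing test, with a stated time of 30 min, at a dose of 100 mg/kg (on this read-out lower numbers stand for less inhibition and higher numbers for more inhibition at the one dose given (going by the name of the read-out)), compound 1 `CCN1CCc2c(c(C)nn2C(=O)Nc2cccc(C(F)(F)F)c2)C1` gives 56.1% and stands lowest of the two numbers recorded so far. For the measured compounds named here, compound 2 `CCN1CCc2c(c(C(C)(C)C)nn2C(=O)Nc2ccc(F)cc2F)C1` in this assay gives 71.9%, a number that lies beyond the scatter above compound 1; compound 2 differs from compound 1 in more than one place, so the two values show only that the pair of changes taken together goes with more inhibition.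

Compound 3 `CCN1CCc2c(c(C(C)(C)C)nn2C(=O)Nc2cccc(C(F)(F)F)c2)C1` is not yet measured. It differs from compound 1 by a single change, (tert-butyl in place of methyl on an aromatic carbon). Compound 2 carries the same tert-butyl on the core and gives the higher of the two known values, so an upward step in this assay is expected, of moderate size and probably beyond the scatter, though the aryl group of compound 3 matches compound 1 and not compound 2, which leaves the size uncertain. The step from compound 1 to compound 3 is estimated as a number 8.9 percentage points higher from compound 1 to compound 3 (within the scatter). For compound 3 the expected value in this assay is 65%, with a range from 50% to 80%.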

Compound 3, a percentage reported as inhibition, in the whole organism at one dose (the size of the read-out at that dose, not a potency): 61.4%
Beside the measured number, compound 3's estimate is 3.6 percentage points above it; the measured number falls inside the stated range.
By their numbers in this assay, from the lowest: compounds 1 and 3 (each within the scatter of the next); then compound 2.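

In this assay, for the compounds shown here, tert-butyl in place of methyl on an aromatic carbon of the shared core, next to the ring nitrogen, gives a number 5.3 percentage points higher from compound 1 to compound 3 (within the scatter) and so isolates this change for the first time, which the earlier pair could not do. This position therefore carries either methyl or tert-butyl, despite the larger group's 4 heavy atoms against 1, with values that stay within the scatter of each other on this read-out at the one dose given. The tert-butyl change alone does not account for the gap beyond the scatter between compound 1 and compound 2, and nothing on hand bears on why this position behaves this way.

From the compounds shown here alone, only methyl and tert-butyl are compared at this carbon, so it remains open what an ethyl, an isopropyl or an aminomethyl group would give there, and whether any group at this position moves the read-out beyond the scatter. Also open, going by these compounds, is how much of the number for compound 2 belongs to its fluorinated aryl group, and whether the same step would hold on that aryl group or at another dose.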